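Replacing a methyl on oxygen in compound 2

The source may report more compounds than this note shows. Statements on the series, on what has been measured and on what is new or still open speak of the compounds shown alone.

In a functional assay on HT-29 cells (Homo sapiens) for cytotoxicity, read by MTT assay, with a stated time of 6 days (a higher number here means that more compound is needed for the effect, a lower number that less compound is needed), compound 1 `COC(=O)c1c(-c2ccc(O)cc2)oc2ccccc2c1=O` gives > 25 ug/mL, which is a limit and not a number. Among the compounds with values here, compound 2 `COc1cc(-c2cc(=O)c3cc(O)ccc3o2)cc(OC)c1OC` gives 7.85 ug/mL, the only actual number so far, so its standing rests on a single reading.

Compound 3 `COc1cc(-c2cc(=O)c3cc(O)ccc3o2)cc(OC)c1O[Si](C)(C)C(C)(C)C` keeps the core of compound 2 and carries one change: a group of 7 heavy atoms (6 carbon, 1 silicon; no ring) in place of one carbon atom, on an oxygen on an aromatic ring. A group of 7 heavy atoms, with no ring, replaces one carbon atom on an oxygen on an aromatic ring.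

Within the data shown here, no measured pair shows this kind of change, so the expectation starts from compound 2 at 7.85 ug/mL. No step beyond the scatter is expected in this assay, with only a slight lean toward more compound being needed. The estimated change is a 1.3-fold higher number from compound 2 to compound 3 (0.11 log units; within the scatter). For compound 3 the expected value is 10 ug/mL, within an estimated range of 3.5 ug/mL to 25 ug/mL.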

Compound 3, concentration for half-maximal effect: 2.63 ug/mL
Estimate against measurement, compound 3: 3.8-fold (0.58 log units) above, outside the stated range (below it).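

In this assay, the oxygen on an aromatic ring in compound 2 accepts far more than a methyl: a group of 7 heavy atoms (6 carbon, 1 silicon; no ring) gives a 3.0-fold lower number from compound 2 to compound 3 (0.47 log units; beyond the scatter). Within the data shown here, this is the only step that can be read, and it shows that the number responds to a change at this oxygen and that the larger group carries no penalty here. Nothing among the data shown gives a cause for this step.

One pair cannot separate the effect of the silicon from that of the number of heavy atoms, so an all-carbon group or a longer chain on the same oxygen would be needed to tell them apart. On these data alone, whether a free hydroxyl there would move the number in either direction also stays open.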